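Swapping a carbamate for phenyl on the chain of compound 1

This account rests on a few compounds, and the source may have more. Where it says the series, first, only, none or still open, it means among the compounds named here.

Measured compounds:
Compound 1, `COC(=O)NC(CC(=O)N1CCC(Cn2c(C)nc3cnccc32)CC1)c1ccccc1`, 12 nM
Compound 2, `Cc1nc2cnccc2n1CC1CCN(S(=O)(=O)CC(C)(C)c2ccccc2)CC1`, 6.2 nM

In a functional assay (plasma) with Oryctolagus cuniculus as the target (on this read-out lower numbers stand for stronger inhibition and higher numbers for weaker inhibition), compound 1 gives 12 nM. Going by the values given here, compound 2, the only other measured compound, gives 6.2 nM in this assay, and the two values lie within the usual scatter of each other, so neither stands apart. Compound 3, `Cc1nc2cnccc2n1CC1CCN(C(=O)CC(c2ccccc2)c2ccccc2)CC1`, has not been measured. It differs from compound 1 by phenyl in place of (methoxycarbonyl)amino on a saturated chain carbon bound to an aromatic carbon and a saturated chain carbon. Among the compounds with values here, no measured pair shows this change, so the step is estimated to be small, a 1.2-fold lower number from compound 1 to compound 3 (0.08 log units; within the scatter), with no clear direction beyond the scatter. Compound 3 is therefore expected to give about 10 nM, within 3 nM to 40 nM.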

Compound 3, half-maximal inhibitory concentration: 7.6 nM
Beside the measured number, compound 3's estimate is 1.3-fold (0.12 log units) above it; the measured number falls inside the stated range.
By their numbers in this assay, from the lowest: compounds 2, 3 and 1 (each within the scatter of the next).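

On this saturated chain carbon, bound to an aromatic carbon and a saturated chain carbon, phenyl replaces (methoxycarbonyl)amino, and in this assay the step stays within the scatter (a 1.6-fold lower number from compound 1 to compound 3 (0.20 log units; within the scatter)). This pair shows that a group with no hydrogen-bond donors or acceptors can stand here and give a number that cannot be told apart from that of the carbamate. Nothing measured here offers a reason for this result. From the compounds shown here alone, it remains open whether an amine, a carboxylic acid or a simple methyl on this carbon would also stay within the scatter.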